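This account rests on a few compounds, and the source may have more. Where it says the series, first, only, none or still open, it means among the compounds named here.

Measured in a functional assay on PC-3 cells (Homo sapiens) for antiproliferative activity, read by MTT assay, with a stated time of 48 h; on this read-out lower numbers stand for stronger inhibition and higher numbers for weaker inhibition:
- Compound 1 `CCn1c(C(=O)NCCN(C)C)ccc1C(CC)(CC)c1ccc(OCCC(O)(CC)CC)c(C)c1`: 870 nM
- Compound 2 `CCC(C)C(NC(=O)c1ccc(C(CC)(CC)c2ccc(OCCC(O)(CC)CC)c(C)c2)n1CC)C(=O)O`: 13800 nM

For the measured compounds named here, compound 2 has the higher of these two numbers, which here means the weaker inhibition, and compound 1 is its only neighbour. Compound 3 `CCn1c(C(=O)NC(CC(=O)O)C(=O)OC)ccc1C(CC)(CC)c1ccc(OCCC(O)(CC)CC)c(C)c1` keeps the shared core and changes only the group on an amide-type nitrogen: a group of 9 heavy atoms (5 carbon, 4 oxygen; no ring) in place of a group of 8 heavy atoms (6 carbon, 2 oxygen; no ring), on an amide-type nitrogen.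

Going by the values given here, one measured step bears on this change: a 16-fold higher number from compound 1 to compound 2 (1.20 log units; beyond the scatter). This large step, beyond the scatter, put 1-carboxy-2-methylbutyl in place of 2-(dimethylamino)ethyl on that same nitrogen. It shows that the number can move far when this group is exchanged. However, the group entering compound 3 resembles 1-carboxy-2-methylbutyl more than it resembles 2-(dimethylamino)ethyl: like the group it replaces, it has no ring and no net charge. Compound 2, at 13800 nM, is therefore the natural reference point, and no step beyond the scatter is expected. Among the compounds with values here, no measured compound carries the entering group, so the range is kept wide. The expected step is a 1.2-fold lower number from compound 2 to compound 3 (0.06 log units; within the scatter). For compound 3 the estimate is 12000 nM, with an expected range from 4000 nM to 36000 nM.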

Compound 3, half-maximal inhibitory concentration: 11200 nM
For compound 3 the middle estimate is 1.1-fold (0.03 log units) above the measured one; the measured number falls inside the stated range.
By their numbers in this assay, from the lowest: compound 1; then compounds 3 and 2 (each within the scatter of the next).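

In this assay, the new group on the amide-type nitrogen in place of 1-carboxy-2-methylbutyl gives a 1.2-fold lower number from compound 2 to compound 3 (0.09 log units; within the scatter), so these two compounds cannot be told apart, even though the entering group has 9 heavy atoms against 8 and 3 hydrogen-bond acceptors against 1. Measured against 2-(dimethylamino)ethyl, the same entering group gives a 13-fold higher number from compound 1 to compound 3 (1.11 log units; beyond the scatter), so the large gap from compound 1 is now seen with two different groups rather than one. No measurement shown here explains why these numbers fall as they do.

Among these three compounds, 2-(dimethylamino)ethyl is the only group that stands apart, so it remains open whether another amine on this nitrogen, such as a longer chain ending in dimethylamino or a morpholine, would give a number close to that of compound 1. As far as these compounds go, it is equally open whether a plain alkyl chain, or a group carrying a methyl ester but no free carboxylic acid, would give a number close to those of compound 2 and compound 3.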